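Swapping One Ring Group on Compound 2

The source may report more compounds than this note shows. Statements on the series, on what has been measured and on what is new or still open speak of the compounds shown alone.

In a physicochemical assay for solubility, measured as kinetic solubility (a higher number here means a more soluble compound, a lower number a less soluble compound), compound 1 `CCC/N=C1\S/C(=C\c2ccc(O)cc2)C(=O)N1c1ccccc1C` gives 79000 nM and compound 2 `CCC/N=C1\S/C(=C\c2ccc(O)c(Cl)c2)C(=O)N1C1CCOCC1` gives 70000 nM, so these two numbers lie within the usual scatter of each other. Compound 3 `CCC/N=C1\S/C(=C\c2ccc(O)c(Cl)c2)C(=O)N1c1ccccc1OC` keeps the rest of compound 2 but carries 2-methoxyphenyl in place of oxan-4-yl on an amide-type nitrogen in a ring. Among the measured compounds shown here, no measured pair differs in one place only, so the data give no direct measure of this swap. The closest guide is compound 1, which also has an aromatic ring on that nitrogen and gives 79000 nM, though it differs from compound 3 elsewhere too. A modest fall in this assay is therefore expected, with the estimated change being a 1.4-fold lower number from compound 2 to compound 3 (0.15 log units; within the scatter). The expected value for compound 3 is 50000 nM, within an estimated range of 15000 nM to 90000 nM.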

Compound 3, solubility: 79000 nM
For compound 3 the middle estimate is 1.6-fold (0.20 log units) below the measured one, and the stated range covers the measured number.
By their numbers in this assay, from the lowest: compounds 2, 1 and 3 (each within the scatter of the next).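

Among the compounds shown here, this is the first direct reading at the amide-type nitrogen in a ring: with the rest of compound 2 unchanged, placing 2-methoxyphenyl in place of oxan-4-yl gives a 1.1-fold higher number from compound 2 to compound 3 (0.05 log units; within the scatter) in this assay for this pair. At this position, then, a six-membered non-aromatic ring and a six-membered aromatic ring bearing methoxy can be exchanged without a difference that stands out from the scatter, even though the entering group is the larger by heavy-atom count. Nothing available explains this outcome.

The compounds shown leave open whether a group of a different kind at this nitrogen, such as an amine or a carboxylic acid, would give a reading beyond the scatter. A single swap also cannot show whether the same exchange would behave alike on another version of the shared core.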